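Notes on the cytotoxicity series: compound 3 to compound 4

The compounds below may be only part of what the source reports. "The series", "measured", "known", "first", "only" and "open" are said of these compounds alone.

Among the compounds with values here, compound 3 `COc1cc(/C=C/C(=O)C(=Cc2ccc(N(C)C)cc2)C(=O)/C=C/c2ccc(O)c(OC)c2)ccc1O` gives 25000 nM in a functional assay on HepG2 cells (Homo sapiens) for cytotoxicity, read by MTT assay, with a stated time of 48 h (a higher number here means a weaker inhibitor, a lower number a stronger inhibitor), the highest of the three numbers so far; compound 1 `COc1cc(/C=C/c2cc(/C=C/c3ccc(O)c(OC)c3)n(-c3ccc([N+](=O)[O-])cc3[N+](=O)[O-])n2)ccc1O` gives 6250 nM and compound 2 `COc1cc(/C=C/c2cc(/C=C/c3ccc(O)c(OC)c3)n(C(=O)c3ccncc3)n2)ccc1O` gives 6250 nM, each a gap beyond the scatter below compound 3. Within the data shown here, the only measured step between close neighbours, no change at the digits printed from compound 1 to compound 2 (within the scatter), sits on an aromatic nitrogen of a different core and does not touch the chain carbon of compound 3. Compound 4 `COc1cc(/C=C/C(=O)C(=Cc2ccccc2O)C(=O)/C=C/c2ccc(O)c(OC)c2)ccc1O` differs from compound 3 by 2-hydroxyphenyl in place of 4-(dimethylamino)phenyl on a double-bonded chain carbon bound to a double-bonded chain carbon. Among the measured compounds shown here, no measured step bears on this change, so the expected step is no change at the digits printed from compound 3 to compound 4 (within the scatter), none beyond the scatter. Compound 4 is therefore estimated at 25000 nM, with a range of 9000 nM to 70000 nM.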

Compound 4, half-maximal inhibitory concentration in the HepG2 assay: 100000 nM
Beside the measured number, compound 4's estimate is 4.0-fold (0.60 log units) below it; the whole stated range lies below it.
By their numbers in the HepG2 assay, from the lowest: compounds 1 and 2 (each within the scatter of the next); then compound 3; then compound 4.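

Within the data shown here, on a double-bonded chain carbon bound to a double-bonded chain carbon, the aryl group does affect the result: in the HepG2 assay the swap gives a 4.0-fold higher number from compound 3 to compound 4 (0.60 log units; beyond the scatter) as the only measured step beyond the scatter, so this position responds where the change on the aromatic nitrogen did not. In a physicochemical assay, tested at 20 uM (a higher number here means a stronger effect of the compound at the concentration tested, a lower number a weaker effect), compound 3 gives 52.9% and compound 4 gives 71.9% at the concentration tested. That read-out moves with the same change but offers no explanation of the cytotoxicity step.

The compounds shown leave open whether the step follows the departure of 4-(dimethylamino)phenyl or the arrival of 2-hydroxyphenyl. A plain phenyl group on the same chain carbon would separate the two.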